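Ring-size and methyl variation in pyridine thiosemicarbazide cytotoxicity

A few compounds are considered here, and "the series" means these few. Any claim that something is new, unique, unknown or untested is made for them only; others in the source may bear on it.

Measured so far:
Compound 1, `N/C(=N\NC(=S)N1CCCCCC1)c1ccccn1`, 89%
Compound 2, `N/C(=N\NC(=S)N1CCCCC1)c1ccccn1`, 88.5%
Compound 3, `Cc1cccc(/C(N)=N/NC(=S)N2CCCCC2)n1`, 85.7%

Three compounds were tested in a functional assay on A-375 cells (Homo sapiens) for cytotoxicity, read by MTT assay, with a stated time of 72 h, tested at 100 uM; on this read-out higher numbers stand for more inhibition of growth at the one concentration tested and lower numbers for less inhibition of growth. Compound 1 gives 89%, compound 2 gives 88.5% and compound 3 gives 85.7%; all three lie within the usual scatter of one another, so no order among them can be claimed. Compound 4, `Cc1cccc(/C(N)=N/NC(=S)N2CCCCCC2)n1`, has not yet been measured in this assay. It is related to compound 1 by methyl in place of hydrogen on an aromatic carbon. The same change, (methyl in place of hydrogen on an aromatic carbon), is already measured: it gave a number 2.8 percentage points lower from compound 2 to compound 3 (within the scatter). The difference between the cores of compound 1 and compound 2 is not broken down here. Since the change from compound 2 to compound 3 stayed within the scatter, compound 4 is expected to show a similarly small step, a number 2.5 percentage points lower from compound 1 to compound 4 (within the scatter). Compound 4 is therefore estimated at 86.5%, between 78% and 93%.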

Compound 4, percent growth inhibition at one concentration: 80.9%
Compound 4: the middle estimate sits 5.6 percentage points above what was measured; the measured number falls inside the stated range.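

In this assay, methyl in place of hydrogen on an aromatic carbon gave a number 8.1 percentage points lower from compound 1 to compound 4 (within the scatter). Set beside the earlier case, the step on the two cores cannot be told apart: the same change on two cores in this assay, a number 2.8 percentage points lower (within the scatter) from compound 2 to compound 3 and a number 8.1 percentage points lower (within the scatter) from compound 1 to compound 4, 5.3 percentage points apart, within the scatter of two such steps. This shows that the change carried from one core to the other without a step beyond the scatter, but it does not show that methyl has a real effect of its own on either core, and it says nothing beyond these two cores or the one concentration tested.

The compounds shown leave open how a larger or different group on that aromatic carbon, such as an ethyl group, a methoxy group or a chlorine atom, would read. They also leave open whether steps beyond the scatter would appear at lower concentrations.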